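A few compounds are considered here, and "the series" means these few. Any claim that something is new, unique, unknown or untested is made for them only; others in the source may bear on it.

In a functional assay on MDA-MB-231 cells (Homo sapiens) for antiproliferative activity, read by sulforhodamine B assay, with a stated time of 72 h (on this read-out lower numbers stand for stronger inhibition and higher numbers for weaker inhibition), compound 1 `COc1ccc(/C=C2\CCC=CC2=O)cc1` gives 1620 nM, compound 2 `COc1ccc(/C=C2\CCC=CC2=O)cc1OC` gives 640 nM and compound 3 `COc1ccc(/C=C2\CCC=CC2=O)c(C)c1` gives 1070 nM. Compound 1 thus stands level with compound 3, and only compound 2 lies clearly lower. Compound 4 `O=C1C=CCC/C1=C\c1ccc(-c2ccccc2)cc1` differs from compound 1 in one place: phenyl in place of methoxy on an aromatic carbon. In short, this is phenyl in place of methoxy on an aromatic carbon. Methoxy in place of hydrogen gives a 2.5-fold lower number from compound 1 to compound 2 (0.40 log units; beyond the scatter) and methyl in place of hydrogen gives a 1.5-fold lower number from compound 1 to compound 3 (0.18 log units; within the scatter), yet neither step removes the methoxy, so they bear only loosely on compound 4 and no step beyond the scatter is expected. For compound 4 the estimated value is 1300 nM, with an expected range from 450 nM to 3800 nM. The expected change is a 1.2-fold lower number from compound 1 to compound 4 (0.10 log units; within the scatter).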

Compound 4, half-maximal inhibitory concentration: 680 nM
Compound 4: the middle estimate sits 1.9-fold (0.28 log units) above what was measured; the range from low to high includes it.
By their numbers in this assay, from the lowest: compounds 2, 4, 3 and 1 (each within the scatter of the next, the first and the last beyond it).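

In this assay compound 2 and compound 3 keep the methoxy, whereas compound 4 replaces it, and phenyl brings a 2.4-fold lower number from compound 1 to compound 4 (0.38 log units; beyond the scatter) at this place. The methoxy is therefore not required here: on this aromatic carbon, para to a group of 8 heavy atoms, a six-membered aromatic ring of carbon only, with no hydrogen-bond acceptor, is tolerated and even gives a lower number. Nothing available explains this change.

As far as these compounds go, whether the result depends on an aromatic ring stays open. So does whether a cyclohexyl ring, an amine or a carboxylic acid at this place would give a similar number.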